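This account rests on a few compounds, and the source may have more. Where it says the series, first, only, none or still open, it means among the compounds named here.

Measured compounds:
compound 1 `COc1ccccc1/C=C(/Sc1ccc(C)cc1)C(=O)c1ccc(Cl)cc1`, 25000 nM
compound 2 `Cc1ccc(S/C(=C/c2cc(C)cc(C)c2)C(=O)c2ccc(Cl)cc2)cc1`, 50000 nM
compound 3 `Cc1ccc(S/C(=C/c2ccc[nH]2)C(=O)c2ccc(Cl)cc2)cc1`, 10000 nM

In a functional assay on DU-145 cells (Homo sapiens) for inhibition, read by trypan blue exclusion, with a stated time of 96 h (on this read-out higher numbers stand for weaker inhibition of growth and lower numbers for stronger inhibition of growth), compound 2 gives the highest of the three numbers. The step of a 2.0-fold higher number from compound 1 to compound 2 (0.30 log units; within the scatter) lies within the scatter, whereas a 5.0-fold lower number from compound 2 to compound 3 (0.70 log units; beyond the scatter) and a 2.5-fold lower number from compound 1 to compound 3 (0.40 log units; beyond the scatter) lie beyond it. Compound 4 `Cc1cc(C)cc(/C=C(/SCc2ccc(Cl)cc2)C(=O)c2ccc(Cl)cc2)c1` differs from compound 2 in one place: 4-chlorobenzyl in place of 4-methylphenyl on a sulfur. Among the compounds with values here, none of the measured steps touches the sulfur; all three exchange the group on the double-bonded chain carbon, so no measured step bears on this change. With nothing to go on, no step beyond the scatter is expected in this assay. Compound 4 is therefore estimated at 50000 nM, with a range from 15000 nM to 150000 nM. The expected step is no change at the digits printed from compound 2 to compound 4 (within the scatter).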

Compound 4, concentration for 50% growth inhibition: 10000 nM
Estimate against measurement, compound 4: 5.0-fold (0.70 log units) above, and the stated range ends above it.
By their numbers in this assay, from the lowest: compounds 3 and 4 (each within the scatter of the next); then compounds 1 and 2 (each within the scatter of the next).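

The group on the sulfur matters in this assay: 4-chlorobenzyl in place of 4-methylphenyl gives a 5.0-fold lower number from compound 2 to compound 4 (0.70 log units; beyond the scatter). Within the data shown here, the earlier steps changed only the group on the double-bonded chain carbon, so this is the first sign that the sulfur substituent also affects growth inhibition. Nothing available explains this step.

This single exchange alters both the link to the ring and the ring substituent, and the compounds shown do not separate the two. Going by these compounds, it also remains open whether a plain benzyl or a longer chain ending in an amine on the sulfur would give a similar result.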